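The source may report more compounds than this note shows. Statements on the series, on what has been measured and on what is new or still open speak of the compounds shown alone.

Of the compounds shown here, two have been measured so far. In a functional assay on A549 cells (Homo sapiens) for antiproliferative activity, read by CCK-8 assay, with a stated time of 72 h (on this read-out lower numbers stand for stronger inhibition and higher numbers for weaker inhibition), compound 1 `O=C(/C=C/c1ccc(COc2ccccc2)cc1)NO` gives 5770 nM. In this assay compound 2 `Nc1ccccc1NC(=O)c1ccc(COc2ccccc2)cc1` gives 6760 nM, a number that sits within the usual scatter of that of compound 1, so the two stand together. Compound 3 `COc1ccc(OCc2ccc(C(=O)Nc3ccccc3N)cc2)cc1` has not been measured; it differs from compound 2 by methoxy in place of hydrogen on an aromatic carbon. Within the data shown here, no step between measured compounds is known, so nothing here shows what this change does. For compound 3 the expected step of a 1.1-fold lower number from compound 2 to compound 3 (0.05 log units; within the scatter) is estimated to stay within the scatter. Compound 3 is expected to give about 6000 nM, between 2500 nM and 15000 nM.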

Compound 3, half-maximal inhibitory concentration: 5530 nM
For compound 3 the middle estimate is 1.1-fold (0.04 log units) above the measured one; the range from low to high includes it.
By their numbers in this assay, from the lowest: compounds 3, 1 and 2 (each within the scatter of the next).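

In this assay, among these compounds, methoxy in place of hydrogen on this aromatic carbon, para to a large group, comes with a 1.2-fold lower number from compound 2 to compound 3 (0.09 log units; within the scatter) and so gives the first measured step: this position carries the added methoxy with no change beyond the scatter. No measurement at hand offers an explanation for this result. As far as these compounds go, whether an amine, a carboxylic acid or a longer chain at this position would shift the number stays open. So does whether methoxy would behave the same way on the core of compound 1.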